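Dichloroanilino to chloroanilino on the shared core

The source may hold more compounds than are shown below. What is called first, only, known or untested is meant among the compounds shown, and "the series" means these compounds.

Two anilino variants of the shared core carry numbers. Compound 1 `CN1CCN(CCCOc2cccc3nc(Nc4ccc(Cl)c(C(F)(F)F)c4)ccc23)CC1` gives 1520 nM in a functional assay on SNB-75 cells (Homo sapiens) for inhibition, read by sulforhodamine B assay, with a stated time of 48 h; on this read-out lower numbers stand for stronger inhibition of growth and higher numbers for weaker inhibition of growth. Compound 2 `CN1CCN(CCCOc2cccc3nc(Nc4ccc(F)c(F)c4)ccc23)CC1` gives 3920 nM in this assay, and the change of aryl group produces a 2.6-fold higher number from compound 1 to compound 2 (0.41 log units; beyond the scatter). Among the compounds with values here, these are the only two results in the set; both sit in the same broad region, and the single recorded step between them is modest.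

As far as these compounds go, compound 3 `CN1CCN(CCCOc2cccc3nc(Nc4cc(Cl)cc(Cl)c4)ccc23)CC1` stands apart: in this assay compound 3 gives "not determined" (no result reported), so its place relative to compound 1 and compound 2 is unknown. Compound 4 `CN1CCN(CCCOc2cccc3nc(Nc4cccc(Cl)c4)ccc23)CC1` differs from compound 3 by hydrogen in place of chloro on an aromatic carbon.

Within the data shown here, no measured step matches this removal of a chloro group, and compound 3 itself supplies no anchor, so the expectation for compound 4 rests on the spread between compound 1 and compound 2. On that basis the step from compound 3 to compound 4 in this assay is expected to be small, in either direction or none beyond the scatter, and the number for compound 4 is expected to fall near the middle of the range the two measured compounds define. Compound 4 is therefore estimated at 3000 nM, within 1200 nM to 7500 nM.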

Compound 4, concentration for 50% growth inhibition: 1380 nM
Compound 4: middle estimate off by 2.2-fold (0.34 log units), on the high side; the range from low to high includes it.
By their numbers in this assay, from the lowest: compounds 4 and 1 (each within the scatter of the next); then compound 2.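

In this assay, the 3-chlorophenyl group can now be set against both earlier aryl groups, and the two comparisons differ: there is a 2.8-fold lower number from compound 2 to compound 4 (0.45 log units; beyond the scatter), but also a 1.1-fold lower number from compound 1 to compound 4 (0.04 log units; within the scatter). The 3-chlorophenyl and 4-chloro-3-(trifluoromethyl)phenyl groups therefore cannot be told apart at this position on the present data, while the 3,4-difluorophenyl group of compound 2 is the only one of the three separated from the others by a step beyond the scatter. The direct step from the 3,5-dichlorophenyl group of compound 3 to the 3-chlorophenyl group of compound 4 cannot be read, so the change from chloro to hydrogen remains without a measured size, and no supporting data on hand explain the differences between these aryl groups.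

Open, as far as these compounds go, is whether a lone fluoro, as in 3-fluorophenyl, or a lone trifluoromethyl, as in 3-(trifluoromethyl)phenyl, would stand with compound 4 or with compound 2 in this assay. Also open, from the compounds shown here alone, are the effects of a nitrile or an amine on this ring.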